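The source may hold more compounds than are shown below. What is called first, only, known or untested is meant among the compounds shown, and "the series" means these compounds.

Measured so far in a functional assay on PC-9 cells (Homo sapiens) for inhibition, read by MTT assay, with a stated time of 72 h; on this read-out lower numbers stand for stronger inhibition and higher numbers for weaker inhibition:
compound 1 `Cc1cc(Nc2cc(-c3ccccc3)[nH]n2)n2nc(SCC3CCCCC3)nc2n1`: > 50000 nM
compound 2 `Cc1cc(Nc2cc(-c3ccccc3)[nH]n2)n2nc(SCc3ccc(Br)cc3)nc2n1`: 4760 nM
compound 3 `Cc1cc(Nc2ccn(Cc3ccc(F)cc3)n2)n2nc(SCc3ccc(Br)cc3)nc2n1`: 19400 nM

Compound 1 gives no number in this assay; its entry is a limit, (the limit of > 50000 nM in this assay, at which 1 of the 3 values shown sits). Compound 4 `Cc1ccc(CSc2nc3nc(C)cc(Nc4cc(-c5ccccc5)[nH]n4)n3n2)cc1` is not yet measured. Against compound 1 it shows (4-methylphenyl in place of cyclohexyl on a saturated chain carbon bound to a sulfur). Among the compounds with values here, the one measured step of this kind is an at least 10-fold lower number from compound 1 to compound 2 (1.02 log units; beyond the scatter), where 4-bromophenyl entered at the same place and the number left the limit. With 4-methylphenyl entering at that place, a step of similar direction is expected for compound 4, though its size is uncertain with a single precedent. Compound 4 is estimated at 8000 nM, within 2500 nM to 30000 nM, which corresponds to an expected step of an at least 6.2-fold lower number from compound 1 to compound 4 (0.79 log units; beyond the scatter).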

Compound 4, half-maximal inhibitory concentration: 7310 nM
Estimate against measurement, compound 4: 1.1-fold (0.04 log units) above; low and high end bracket the measured number.
By their numbers in this assay, from the lowest: compounds 2 and 4 (each within the scatter of the next); then compound 3. At a limit, above all of these: compound 1.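

In this assay, 4-methylphenyl in place of cyclohexyl on a saturated chain carbon bound to a sulfur gives an at least 6.8-fold lower number from compound 1 to compound 4 (0.83 log units; beyond the scatter), so the earlier step no longer rests on 4-bromophenyl alone. The entry for compound 1 is a limit, not a number: the limit of > 50000 nM in this assay, at which 1 of the 4 values shown sits. Methyl in place of bromo on an aromatic carbon gives a 1.5-fold higher number from compound 2 to compound 4 (0.19 log units; within the scatter), so these two groups are not separated in this assay.

Open, from the compounds shown here alone, is whether unsubstituted phenyl, or an amine or carboxylic acid on that ring, keeps this level. Going by these compounds, a longer chain between the sulfur and the ring is also open.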